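The source may hold more compounds than are shown below. What is called first, only, known or untested is meant among the compounds shown, and "the series" means these compounds.

Among the measured compounds shown here, in a functional assay on M21 cells (Homo sapiens) for antiproliferative activity, read by sulforhodamine B assay, with a stated time of 48 h (a higher number here means a weaker inhibitor, a lower number a stronger inhibitor), compound 1 (`COc1ccccc1OS(=O)(=O)c1ccc(N2CCN(C)C2=O)cc1`) gives 21000 nM, the only readable number so far. Compound 2 (`CCN1CCN(c2ccc(S(=O)(=O)Oc3ccccc3OC)cc2)C1=O`) gives > 100000 nM, which is a limit of the assay and not a number. Compound 3 (`CCCCN1CCN(c2ccc(S(=O)(=O)Oc3ccccc3OC)cc2)C1=O`) gives > 100000 nM, which is also a limit. Compound 3 therefore has no exact position and sits with compound 2 on (the limit of > 100000 nM in this assay, at which 2 of the 3 values shown sit).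

The measured steps all change the saturated chain. They show an at least 4.7-fold higher number from compound 1 to compound 2 (0.67 log units; beyond the scatter) and an at least 4.7-fold higher number from compound 1 to compound 3 (0.67 log units; beyond the scatter), while the last comparison is a step that the two limits leave unreadable from compound 2 to compound 3.

Compound 4 (`CCCCN1CCN(c2ccc(S(=O)(=O)Oc3cccc(Br)c3)cc2)C1=O`) keeps the chain of compound 3 but changes the aryl group: 3-bromophenyl in place of 2-methoxyphenyl on an oxygen. This is 3-bromophenyl in place of 2-methoxyphenyl on an oxygen bound to the sulfonyl sulfur. For the measured compounds named here, no measured step touches that place, so none of their sizes can be carried across directly.

The best guide is that compound 1, at 21000 nM, shows that a readable number is possible in this small set. A modest move towards a lower number is possible, but a return to the limit is about as likely. The expected change is an at least 1.6-fold lower number from compound 3 to compound 4 (0.22 log units; that floor lies within the scatter), and this estimate is loose. Compound 4 is estimated at 60000 nM, with an expected range from 10000 nM to 150000 nM.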

Compound 4, half-maximal inhibitory concentration: 35000 nM
Compound 4: the middle estimate sits 1.7-fold (0.23 log units) above what was measured; the range from low to high includes it.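

Placing 3-bromophenyl in place of 2-methoxyphenyl on the oxygen bound to the sulfonyl sulfur gives, in this assay, an at least 2.8-fold lower number from compound 3 to compound 4 (0.45 log units; beyond the scatter). Among the compounds shown here, the earlier steps all changed the saturated chain, so this is the first look at the aryl group on the other side of the sulfonyl sulfur, and it shows that a change there moves the read-out by more than the usual scatter. It also shows that the chain of compound 3 does not by itself keep a compound at the limit, although the value of compound 3 is a limit and not a number, so the step has a floor and no exact size: the limit of > 100000 nM in this assay, at which 2 of the 4 values shown sit.

This single swap removes the methoxy group and brings in the bromine in one move, so the compounds shown cannot tell which of the two changes accounts for the step, or whether the position of the bromine on the ring matters. As far as these compounds go, a plain phenyl or a chlorophenyl on the same oxygen would begin to separate these, and it remains open whether 3-bromophenyl would have a similar effect on the shorter chain of compound 1.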